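Working notes: side-chain swap on the shared core

The source may report more compounds than this note shows. Statements on the series, on what has been measured and on what is new or still open speak of the compounds shown alone.

- compound 1 `O=C1c2c[n+]([O-])c3ccccc3c2C(=O)c2c1c1ccccc1n2Cc1cn(CC(O)CO)nn1` gives 1290 nM as a number
- compound 2 `CC1(C)OC[C@@H](Cn2cc(Cn3c4c(c5ccccc53)C(=O)c3c[n+]([O-])c5ccccc5c3C4=O)nn2)O1` gives > 1000 nM as a limit

Going by the values given here, in a functional assay on MDA-MB-231 cells (Homo sapiens) for cytotoxicity, read by MTT assay, with a stated time of 72 h (on this read-out higher numbers stand for weaker inhibition and lower numbers for stronger inhibition), compound 1 gives 1290 nM as the only number so far, so it has no numerical neighbour to be ranked against. Compound 2 gives > 1000 nM in this assay and this is a limit, not a number.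

The next step leads to compound 3 `O=C1c2c[n+]([O-])c3ccccc3c2C(=O)c2c1c1ccccc1n2CCCCN1CCCCC1` and its difference reads 3-(piperidin-1-yl)propyl in place of 1-(2,3-dihydroxypropyl)-1H-1,2,3-triazol-4-yl on a saturated chain carbon bound to an aromatic nitrogen as the change to consider. Cut one bond further out, (1-(2,3-dihydroxypropyl)-1H-1,2,3-triazol-4-yl)methyl gives way to 4-(piperidin-1-yl)butyl.

Among the compounds with values here, the one measured step that the limit leaves unreadable from compound 1 to compound 2 alters the same side chain but keeps the five-membered aromatic ring, and its size cannot be read. The evidence amounts to the limit of > 1000 nM in this assay, at which 1 of the 2 values shown sits, and offers no size to carry over. No direction is therefore set in this assay and no step beyond the scatter is expected, though the uncertainty stays wide. The expected step reads a 1.6-fold lower number from compound 1 to compound 3 (0.21 log units; within the scatter) as an estimate only. For compound 3 the estimate is 800 nM with an expected range from 150 nM to 3000 nM for now.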

Compound 3, half-maximal inhibitory concentration: 610 nM
Compound 3: middle estimate off by 1.3-fold (0.12 log units), on the high side; the range from low to high includes it.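

In this assay, the position on a saturated chain carbon bound to an aromatic nitrogen now gives its first readable step, with 3-(piperidin-1-yl)propyl in place of 1-(2,3-dihydroxypropyl)-1H-1,2,3-triazol-4-yl: a 2.1-fold lower number from compound 1 to compound 3 (0.33 log units; beyond the scatter). The entering group has no five-membered aromatic ring and 0 hydrogen-bond donors, so in this pair neither feature of the leaving group is needed to keep a measurable value in this assay. Compound 2 carries a limit and not a number, so its step from compound 1 cannot be read and it gives no size to set beside this change: the limit of > 1000 nM in this assay, at which 1 of the 3 values shown sits.

The change replaces the ring, the two hydroxyl groups and the chain in a single step, and the compounds shown do not tell which of these parts accounts for the difference. A morpholine or a dimethylamine in place of the piperidine, or a shorter or longer chain carrying the same piperidine, would show whether the amine or the chain is what matters at this position.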